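The source may report more compounds than this note shows. Statements on the series, on what has been measured and on what is new or still open speak of the compounds shown alone.

Compound 1 `CNC(=O)N1CCCc2ccc(NC(=O)c3ccc(-c4cc[nH]n4)cc3)cc21` gives 92.5% in a functional assay on MV4-11 cells (Homo sapiens) for antiproliferative activity, with a stated time of 6 days, tested at 1.56 uM; a higher number here means a stronger effect of the compound at the concentration tested, a lower number a weaker effect. Compound 2 `CNC(=O)N1CCCc2ccc(NC(=O)c3cccc(-c4ccn(S(C)(=O)=O)n4)c3)cc21` gives 4.03% in this assay. Compound 3 `CNC(=O)N1CCCc2ccc(NC(=O)c3cccc(-c4cc[nH]n4)c3)cc21` gives 27.3% in this assay.

Compound 1 thus stands highest of the three, beyond the scatter above both compound 3 and compound 2. Compound 4 `CNC(=O)N1CCCc2ccc(NC(=O)c3ccc(-c4cnn(C(C)=O)c4)cc3)cc21` differs from compound 1 by 1-acetyl-1H-pyrazol-4-yl in place of 1H-pyrazol-3-yl on an aromatic carbon. Going by the values given here, the only measured step that bears on capping the pyrazole nitrogen is a number 23.3 percentage points higher from compound 2 to compound 3 (beyond the scatter); read in reverse, capping costs a modest amount, though that step involved methylsulfonyl rather than acetyl and a different attachment point. A drop beyond the scatter is therefore expected, and the step of a number 47.5 percentage points lower from compound 1 to compound 4 (beyond the scatter) is the estimate. Compound 4 is expected to give about 45%, within 10% to 80%.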

Compound 4, a percentage reported as inhibition, at one concentration (the size of the read-out at that concentration, not a potency): 23.9%
The estimate for compound 4 lay 21.1 percentage points above the measured number, and the stated range covers the measured number.
By their numbers in this assay, from the lowest: compound 2; then compounds 4 and 3 (each within the scatter of the next); then compound 1.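

Setting 1-acetyl-1H-pyrazol-4-yl in place of 1H-pyrazol-3-yl, para to a large group, gives a number 68.6 percentage points lower from compound 1 to compound 4 (beyond the scatter) in this assay. This shows that the high number of compound 1 does not survive every pyrazole at this place on the ring. The change alters the attachment point and adds the acetyl group together, so the loss cannot be divided between them, and no measurement here explains it.

On these data alone, whether an uncapped 1H-pyrazol-4-yl or a pyrazole carrying a methyl group on nitrogen would keep that number remains open.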